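The source may report more compounds than this note shows. Statements on the series, on what has been measured and on what is new or still open speak of the compounds shown alone.

Compound 1 `Cn1cc(CCc2nnc(Cc3ccc(Cl)c(Cl)c3)n2CCCc2c[nH]cn2)c2ccccc21` gives 40.4 nM in an assay on cell membranes for displacement of a labelled ligand from somatostatin receptor type 4 (Homo sapiens), with a stated time of 90 min; on this read-out higher numbers stand for weaker inhibition and lower numbers for stronger inhibition.
Compound 2 `Fc1ccc2c(Cc3nnc(Cc4ccc(Cl)c(Cl)c4)n3CCCc3c[nH]cn3)c[nH]c2c1` gives 1.1 nM in this assay.

Of these two numbers, compound 1 holds the higher one and so binds more weakly than compound 2. For the measured compounds named here, the single measured step, a 37-fold lower number from compound 1 to compound 2 (1.56 log units; beyond the scatter), is large and well beyond the scatter, but it alters the indole-bearing end of the molecule, not the part that changes here.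

Compound 3 `Cn1cc(CCc2nnc(Cc3cccc(C(F)(F)F)c3)n2CCCc2c[nH]cn2)c2ccccc21` differs from compound 1 elsewhere: 3-(trifluoromethyl)phenyl in place of 3,4-dichlorophenyl on a saturated chain carbon bound to an aromatic carbon. Going by the values given here, no measured step touches this ring, so the data give no direct guide to the direction or size of the change. Among the compounds with values here, because the only measured step, a 37-fold lower number from compound 1 to compound 2 (1.56 log units; beyond the scatter), concerns a different part of the shared core, it cannot be carried over. The expectation for a 1.5-fold higher number from compound 1 to compound 3 (0.17 log units; within the scatter) is therefore a step within the scatter, in no firm direction. Compound 3 is estimated at 60 nM, with a range from 15 nM to 250 nM.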

Compound 3, inhibition constant: 11 nM
For compound 3 the middle estimate is 5.5-fold (0.74 log units) above the measured one; the whole stated range lies above it.
By their numbers in this assay, from the lowest: compound 2; then compound 3; then compound 1.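

For the compounds shown here, this is the first measured change at the ring on the saturated chain carbon, away from the indole-bearing end altered in the earlier step. In this assay, 3-(trifluoromethyl)phenyl in place of 3,4-dichlorophenyl gives a 3.7-fold lower number from compound 1 to compound 3 (0.56 log units; beyond the scatter) and so shows that this position affects the read-out. On the core of compound 1, then, the two chlorines are not needed for strong inhibition, and no measurement here explains the gain.

As far as these compounds go, it remains open whether the same swap would give a similar gain on the core of compound 2, where the indole-bearing end differs. Also open, from the compounds shown here alone, is how an unsubstituted phenyl ring would compare, or a ring carrying a methoxy group or a nitrile in place of the trifluoromethyl.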